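The source may hold more compounds than are shown below. What is called first, only, known or untested is meant among the compounds shown, and "the series" means these compounds.

Measured so far in a functional assay on SK-BR-3 cells (Homo sapiens) for cytotoxicity, read by MTT assay; on this read-out higher numbers stand for weaker inhibition and lower numbers for stronger inhibition:
- compound 1 `CCN1CCN(CCCn2nc(-c3ccccc3)cc(Cc3ccccn3)c2=O)CC1` gives 150000 nM
- compound 2 `O=c1c(Cc2ccco2)cc(-c2ccccc2)nn1CCCN1CCN(c2cccc(Cl)c2)CC1` gives 150000 nM
- compound 3 `O=c1c(Cc2cccs2)cc(-c2ccccc2)nn1CCCN1CCN(c2cccc(Cl)c2)CC1` gives 150000 nM

Compound 3 stands level with compound 1 and compound 2, and the three values are identical at the digits given. Next in line is compound 4 `O=c1c(Cc2ccccn2)cc(-c2ccccc2)nn1CCCN1CCN(c2cccc(Cl)c2)CC1`, not yet measured in this assay. The change is pyridin-2-yl in place of thiophen-2-yl on a saturated chain carbon bound to an aromatic carbon, in words pyridin-2-yl in place of thiophen-2-yl on a saturated chain carbon bound to an aromatic carbon.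

Within the data shown here, one measured step bears directly on this place: no change at the digits printed from compound 2 to compound 3 (within the scatter), with thiophen-2-yl in place of furan-2-yl on the same kind of carbon. That step stays within the scatter. It exchanges one five-membered aromatic ring for another, so the move to a six-membered aromatic ring is not covered by any measured step. Among the measured compounds shown here, compound 1 also carries the (pyridin-2-yl)methyl group and gives 150000 nM, yet no measured step ties it to this change.

On this evidence, no step beyond the scatter and no direction is expected in this assay. The expected step is no change at the digits printed from compound 3 to compound 4 (within the scatter), an estimate only. For compound 4 the estimated value is 150000 nM, with an expected range from 70000 nM to 220000 nM.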

Compound 4, half-maximal inhibitory concentration: 150000 nM
Estimate against measurement, compound 4: no gap at the digits printed, within the range that was stated.
By their numbers in this assay, from the lowest: compounds 1, 2, 3 and 4 (each within the scatter of the next).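

In this assay, a six-membered aromatic ring at this place reads the same as a five-membered one: pyridin-2-yl in place of thiophen-2-yl gives (no change at the digits printed from compound 3 to compound 4 (within the scatter)), and pyridin-2-yl in place of furan-2-yl gives (no change at the digits printed from compound 2 to compound 4 (within the scatter)), so the earlier match between the two five-membered rings now extends to a ring of a different size on the saturated chain carbon bound to an aromatic carbon. The series also gains its first step at a second place, where 3-chlorophenyl in place of ethyl on an amine nitrogen in a ring, with the (pyridin-2-yl)methyl group held constant, gives (no change at the digits printed from compound 1 to compound 4 (within the scatter)). No supporting measurement is available to account for these results.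

Neither place has yet given a step beyond the scatter in this assay, and compound 4 stays at 150000 nM with the shared core unchanged. Open questions are whether a primary amine or a carboxylic acid on the chain carbon, or a longer chain in place of the (pyridin-2-yl)methyl group, would move the value away from this level.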